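This account rests on a few compounds, and the source may have more. Where it says the series, first, only, none or still open, it means among the compounds named here.

Three compounds share one core and differ only at a saturated chain carbon bound to an oxygen on a saturated carbon. In a functional assay on HEK293 cells for agonist activity at G-protein coupled receptor 39 (Homo sapiens), read by scintillation proximity assay and inositol phosphate accumulation, with a stated time of 75 min (a lower number here means that less compound is needed, a higher number that more compound is needed for the effect), compound 3 `Cc1nn(-c2ncnc3nc[nH]c23)c2c1C(OCCn1nccc1C)CC(=O)N2` gives 1620 nM. Compound 1 `Cc1nn(-c2ncnc3nc[nH]c23)c2c1C(C(=O)NCc1ccc(F)cc1)CC(=O)N2` gives 1220 nM, which lies within the scatter of the number for compound 3, while compound 2 `Cc1nn(-c2ncnc3nc[nH]c23)c2c1C(OCc1ccccc1C#N)CC(=O)N2` gives 127 nM, a clearly lower number. Compound 4 `Cc1nn(-c2ncnc3nc[nH]c23)c2c1C(OCc1ccccc1Cl)CC(=O)N2` carries 2-chlorophenyl in place of (5-methyl-1H-pyrazol-1-yl)methyl on a saturated chain carbon bound to an oxygen on a saturated carbon. Going by the values given here, one measured step bears on this change and runs the other way: a 13-fold higher number from compound 2 to compound 3 (1.11 log units; beyond the scatter), where a six-membered aromatic ring of carbon only gave way to a five-membered aromatic ring with 2 hetero atoms. Restoring such a ring in compound 4 is therefore expected to lower the number by about as much, an 11-fold lower number from compound 3 to compound 4 (1.03 log units; beyond the scatter). Compound 4 is estimated at 150 nM, with a range from 50 nM to 500 nM.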

Compound 4, half-maximal effective concentration: 47 nM
Estimate against measurement, compound 4: 3.2-fold (0.50 log units) above; the measured number lies below the stated range.
By their numbers in this assay, from the lowest: compound 4; then compound 2; then compounds 1 and 3 (each within the scatter of the next).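

Putting 2-chlorophenyl in place of (5-methyl-1H-pyrazol-1-yl)methyl gives a 34-fold lower number from compound 3 to compound 4 (1.54 log units; beyond the scatter) and shows that the low number at this position does not depend on the nitrile of compound 2. The group on the aromatic ring still matters, since chloro in place of cyano on an aromatic carbon gives a 2.7-fold lower number from compound 2 to compound 4 (0.43 log units; beyond the scatter) as a modest step beyond the scatter. As far as these compounds go, whether a methoxy group or an amine in place of chloro would keep the number this low stays open. The available evidence offers no explanation for either step.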